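Fluoro in place of benzyloxy on a chalcone scaffold

The compounds below may be only part of what the source reports. "The series", "measured", "known", "first", "only" and "open" are said of these compounds alone.

Measured compounds:
compound 1 `O=C(/C=C/c1cccc([N+](=O)[O-])c1)c1ccccc1` gives 99.7%
compound 2 `O=C(/C=C/c1ccc(OCc2ccccc2)cc1)c1ccccc1` gives 49.5%

In a functional assay on HCT-116 cells (Homo sapiens) for antiproliferative activity, read by sulforhodamine B assay, with a stated time of 3 days, tested at 50 uM (a higher number here means a stronger effect of the compound at the concentration tested, a lower number a weaker effect), compound 1 reaches 99.7%, the higher of the two numbers recorded. Compound 2 carries a benzyloxy group where compound 1 carries a nitro group, and the substituent also sits at a different position. In this assay compound 2 gives 49.5%, the lowest of the two values; compound 1 stands a long way higher, well beyond the scatter. Within the data shown here, no pair of measured compounds differs in only one place, so no single measured step is available to guide the next change.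

Compound 3 `O=C(/C=C/c1ccc(F)cc1)c1ccccc1` has not yet been measured in this assay. Its difference from compound 2 is fluoro in place of benzyloxy on an aromatic carbon. Among the measured compounds shown here, with only two numbers in hand and no isolated step, the expectation for compound 3 rests on the range those numbers span. Compound 3 is expected to land somewhat above compound 2, with a step from compound 2 to compound 3 of a number 12.5 percentage points higher from compound 2 to compound 3 (beyond the scatter), a shift close to the edge of the usual scatter. In this assay compound 3 is estimated at 62%, within a range of 25% to 95%.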

Compound 3, a percentage reported as inhibition, at one concentration (the size of the read-out at that concentration, not a potency): 100%
Compound 3: middle estimate off by 38 percentage points, on the low side, outside the stated range (above it).
By their numbers in this assay, from the lowest: compound 2; then compounds 1 and 3 (each within the scatter of the next).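

In this assay, among these compounds, the exchange of benzyloxy for fluoro gives the first step that can be read in one place, a number 50.5 percentage points higher from compound 2 to compound 3 (beyond the scatter), and it is large. It shows that the group on this aromatic carbon, para to a large group, can alone move the read-out by a wide margin, and that the higher read-out here goes with the loss of the whole benzyloxy group, ring included, in favour of a single fluorine. The read-out is the size of the effect at one concentration rather than a potency, and nothing at hand says why this change raises it.

On these data alone, whether the read-out follows the size of the group at this carbon stays open, since a methoxy, a chloro or an amine there would fall between the two ends or break that order. A nitro group on this same carbon would also separate the effect of the group from the effect of its place, which the two earlier compounds could not do.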